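This account rests on a few compounds, and the source may have more. Where it says the series, first, only, none or still open, it means among the compounds named here.

Measured compounds in a functional assay (muscle tissue) with Cavia porcellus as the target; on this read-out lower numbers stand for stronger inhibition and higher numbers for weaker inhibition:
compound 1 `CC1=NC(C)=C([N+](=O)[O-])C(c2cccc([N+](=O)[O-])n2)/C1=C(/O)OCCc1ccccc1` gives 4740 nM
compound 2 `CC1=NC(C)=C([N+](=O)[O-])C(c2ncccc2[N+](=O)[O-])/C1=C(/O)OCCc1ccccc1` gives 77700 nM
compound 3 `CC1=NC(C)=C([N+](=O)[O-])C(c2cccc(-c3ccccc3)n2)/C1=C(/O)OCCc1ccccc1` gives 8380 nM

Compounds 1 and 2 have the same atoms joined differently; the change between the cores is 3-nitropyridin-2-yl in place of 6-nitropyridin-2-yl on a saturated ring carbon and it made a 16-fold higher number from compound 1 to compound 2 (1.21 log units; beyond the scatter). Compound 3 differs from compound 1 by phenyl in place of nitro on an aromatic carbon, a change that made a 1.8-fold higher number from compound 1 to compound 3 (0.25 log units; within the scatter).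

Compound 4 `CC1=NC(C)=C([N+](=O)[O-])C(c2ncccc2-c2ccccc2)/C1=C(/O)OCCc1ccccc1` has not yet been measured in this assay. It differs from compound 2 by phenyl in place of nitro on an aromatic carbon. Going by the values given here, this is the same kind of change as the one from compound 1 to compound 3, but not the same: there the group sat next to the ring nitrogen and meta to a large group, here it sits ortho to a large group and two atoms from the ring nitrogen.

Among the compounds with values here, with only the step from compound 1 to compound 3 as a guide, compound 4 is expected to stand close to compound 2 in this assay, with a step of about a 1.2-fold higher number from compound 2 to compound 4 (0.06 log units; within the scatter), because a 1.8-fold higher number from compound 1 to compound 3 (0.25 log units; within the scatter) was within the scatter. Compound 4 is accordingly estimated at 90000 nM, with a range from 30000 nM to 300000 nM.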

Compound 4, half-maximal inhibitory concentration: 3350 nM
For compound 4 the middle estimate is 27-fold (1.43 log units) above the measured one, and the stated range ends above it.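

In this assay, phenyl in place of nitro on an aromatic carbon gives a 23-fold lower number from compound 2 to compound 4 (1.37 log units; beyond the scatter), and this change does not carry over as a constant step between the two cores: the same change on two cores in this assay, a 1.8-fold higher number (0.25 log units; within the scatter) from compound 1 to compound 3 and a 23-fold lower number (1.37 log units; beyond the scatter) from compound 2 to compound 4, 41-fold (1.61 log units) apart, beyond the scatter of two such steps

In compound 2 the replaced nitro stands ortho to a large group and two atoms from the ring nitrogen, so for this change the outcome differs with the core and the place of substitution. Two pairs cannot separate the place of the group from anything else that differs between the cores, and they do not show whether the large step reflects the loss of nitro, the arrival of phenyl, or both.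

Going by these compounds, it remains open whether a smaller group at the same place, such as an amine, a methyl or a chlorine, would follow phenyl or nitro. On these data alone, it is also open whether a carboxylic acid or a longer chain there would keep the number reached by compound 4.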